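A few compounds are considered here, and "the series" means these few. Any claim that something is new, unique, unknown or untested is made for them only; others in the source may bear on it.

Measured compounds:
compound 1 `CCn1c([C@@H](C)NS(=O)(=O)c2ccc(Cl)cc2)nc2cc(C#N)ccc21`, 71 mL.min-1.g-1
compound 2 `CCn1c([C@@H](C)NS(=O)(=O)c2ccc(C#N)cc2)nc2ccc(C(F)(F)F)cc21`, 34 mL.min-1.g-1

In an ADME assay (liver) for metabolic stability, with Liver microsome (Homo sapiens) as the target, read by LC-MS, using microsomes and NADPH, with a stated time of 5 min, at 37 degrees C (on this read-out higher numbers stand for fast clearance and lower numbers for slow clearance), compound 1 gives 71 mL.min-1.g-1, while compound 2 gives 34 mL.min-1.g-1. Compound 2 therefore stands lowest of the two numbers, and its gap to compound 1 lies beyond the usual scatter of repeated measurements. For the measured compounds named here, the two compounds differ in more than one place, so no single step can be drawn between them; only their two values speak. Compound 3 `CCn1c([C@@H](C)NS(=O)(=O)c2cn(C)c(C)n2)nc2ccc(C(F)(F)F)cc21` has not yet been measured in this assay. It differs from compound 2 in one place: 1,2-dimethyl-1H-imidazol-4-yl in place of 4-cyanophenyl on a sulfonyl sulfur. Going by the values given here, no step between measured compounds covers this kind of change. The account expects a modest move toward slower clearance, a 1.7-fold lower number from compound 2 to compound 3 (0.23 log units; within the scatter), though a result within the scatter of compound 2 would not be surprising. Compound 3 is accordingly estimated at 20 mL.min-1.g-1 in this assay, with a range from 8 mL.min-1.g-1 to 50 mL.min-1.g-1.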

Compound 3, intrinsic clearance in microsomes: 43 mL.min-1.g-1
Estimate against measurement, compound 3: 2.2-fold (0.33 log units) below; low and high end bracket the measured number.
By their numbers in this assay, from the lowest: compounds 2, 3 and 1 (each within the scatter of the next, the first and the last beyond it).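

In this assay, 1,2-dimethyl-1H-imidazol-4-yl in place of 4-cyanophenyl on a sulfonyl sulfur gives a 1.3-fold higher number from compound 2 to compound 3 (0.10 log units; within the scatter), so the two numbers cannot be told apart. For the compounds shown here, this is the first reading of a single change at this place, which compound 1 and compound 2 could not give because they differ in more than one place. It shows that, for this pair, exchanging a six-membered aromatic ring of carbon only for a five-membered aromatic ring with 2 hetero atoms leaves clearance within the scatter, and no measurement given here bears on why.

As far as these compounds go, it remains open whether a non-aromatic group on the sulfonyl sulfur, such as a piperidine ring or a simple methyl, would read the same way. From the compounds shown here alone, it is also open whether this exchange would give a similar step on the core of compound 1.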